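Pyrrolidin-1-yl to piperidin-1-yl, carried to a second core

A few compounds are considered here, and "the series" means these few. Any claim that something is new, unique, unknown or untested is made for them only; others in the source may bear on it.

Measured so far:
compound 1, `COc1cc2c(Oc3ccc(NC(=O)c4nn(-c5ccccc5OC(F)(F)F)c(=O)cc4C)cc3F)ccnc2cc1OCCCN1CCCC1`, gives 180 nM in a functional assay on HT-29 cells (Homo sapiens) for inhibition, read by MTT assay, with a stated time of 72 h; a lower number here means a stronger inhibitor, a higher number a weaker inhibitor.
compound 2, `COc1cc2c(Oc3ccc(NC(=O)c4nn(-c5ccccc5OC(F)(F)F)c(=O)cc4C)cc3F)ccnc2cc1OCCCN1CCCCC1`, gives 190 nM in this assay.
compound 3, `COc1cc2c(Oc3ccc(NC(=O)c4nn(-c5ccc(Cl)cc5)c(=O)cc4C)cc3F)ccnc2cc1OCCCN1CCCC1`, gives 260 nM in this assay.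

Within the core of compound 1, the change piperidin-1-yl in place of pyrrolidin-1-yl on a saturated chain carbon, three bonds along the chain from an oxygen on an aromatic ring produced a 1.1-fold higher number from compound 1 to compound 2 (0.02 log units; within the scatter). The core of compound 3 differs from that of compound 1 by 4-chlorophenyl in place of 2-(trifluoromethoxy)phenyl on an aromatic nitrogen, a change that on its own gave a 1.4-fold higher number from compound 1 to compound 3 (0.16 log units; within the scatter). All three values sit within the scatter of one another, so no order among them can be read.

Compound 4, `COc1cc2c(Oc3ccc(NC(=O)c4nn(-c5ccc(Cl)cc5)c(=O)cc4C)cc3F)ccnc2cc1OCCCN1CCCCC1`, stands to compound 3 as compound 2 stands to compound 1: the difference is piperidin-1-yl in place of pyrrolidin-1-yl on a saturated chain carbon, three bonds along the chain from an oxygen on an aromatic ring. The place is described in the same words for both pairs, so this is taken as the same change on a second core. The expectation for compound 4 is therefore a step near a 1.1-fold higher number from compound 3 to compound 4 (0.03 log units; within the scatter) in this assay, because a 1.1-fold higher number from compound 1 to compound 2 (0.02 log units; within the scatter) stayed within the scatter. Compound 4 is estimated at 280 nM, with a plausible range from 150 nM to 520 nM.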

Compound 4, half-maximal inhibitory concentration: 360 nM
For compound 4 the middle estimate is 1.3-fold (0.11 log units) below the measured one, and the stated range covers the measured number.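

In this assay, piperidin-1-yl in place of pyrrolidin-1-yl on the core of compound 3 gave a 1.4-fold higher number from compound 3 to compound 4 (0.14 log units; within the scatter), and this step does not differ from the one on the core of compound 1: the same change on two cores in this assay, a 1.1-fold higher number (0.02 log units; within the scatter) from compound 1 to compound 2 and a 1.4-fold higher number (0.14 log units; within the scatter) from compound 3 to compound 4, 1.3-fold (0.12 log units) apart, within the scatter of two such steps. The other change, 4-chlorophenyl in place of 2-(trifluoromethoxy)phenyl on an aromatic nitrogen, gave a 1.9-fold higher number from compound 2 to compound 4 (0.28 log units; within the scatter), and it too reads the same with either amine: the same change on two cores in this assay, a 1.4-fold higher number (0.16 log units; within the scatter) from compound 1 to compound 3 and a 1.9-fold higher number (0.28 log units; within the scatter) from compound 2 to compound 4, 1.3-fold (0.12 log units) apart, within the scatter of two such steps. So the pyrrolidin-1-yl to piperidin-1-yl change carried between these two cores without a step beyond the scatter, but with every step inside the scatter and only two cores in a single assay, this does not establish a direction for the change or show that it would behave the same way on other cores.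

The compounds shown leave open how a morpholin-4-yl or dimethylamino group in place of piperidin-1-yl, or a longer chain than 3-(piperidin-1-yl)propyl, would read in this assay. They also leave open whether the same step holds with an unsubstituted phenyl on the aromatic nitrogen.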